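The source may hold more compounds than are shown below. What is called first, only, known or untested is meant among the compounds shown, and "the series" means these compounds.

Measured compounds:
Compound 1 `Cc1oc(-c2ccccc2Cl)nc1CN1CCC(C(=O)NCCCN2C[C@H](C)C[C@H](C)C2)CC1` gives 352 10^-6 cm/s in a physicochemical assay for permeability, using PAMPA; a higher number here means that the compound crosses the layer faster, a lower number that the compound crosses the layer more slowly.
Compound 3 `Cc1ccc(-c2nc(CN3CCC(C(=O)NCCCN4C[C@H](C)C[C@H](C)C4)CC3)c(C)o2)cc1` gives 274 10^-6 cm/s in this assay.
Compound 2 `Cc1oc(-c2c(Cl)cccc2C(F)(F)F)nc1CN1CCC(C(=O)NCCCN2C[C@H](C)C[C@H](C)C2)CC1` has "not determined" (no result reported) in this assay.

Among the measured compounds shown here, only two numbers are available, and they sit close together: the step of a 1.3-fold lower number from compound 1 to compound 3 (0.11 log units; within the scatter) is within the scatter, so compound 3 and compound 1 cannot be told apart on these values. Compound 2 adds nothing here, since no number was obtained for it.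

Compound 4 `Cc1cc(C)cc(-c2nc(CN3CCC(C(=O)NCCCN4C[C@H](C)C[C@H](C)C4)CC3)c(C)o2)c1` has not yet been measured. It differs from compound 3 in one place: 3,5-dimethylphenyl in place of 4-methylphenyl on an aromatic carbon. For the measured compounds named here, the single measured step, a 1.3-fold lower number from compound 1 to compound 3 (0.11 log units; within the scatter), also exchanged one six-membered carbon ring for another on the same position of the shared core and produced no change beyond the scatter. Going by the values given here, no measured pair involves a 3,5-dimethylphenyl group, so the expectation rests on that one step alone. The step expected from compound 3 to compound 4 is therefore a 1.1-fold higher number from compound 3 to compound 4 (0.04 log units; within the scatter), that is, no change beyond the scatter. For compound 4 the estimated value in this assay is 300 10^-6 cm/s, with a likely range from 150 10^-6 cm/s to 600 10^-6 cm/s.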

Compound 4, apparent permeability: 864 10^-6 cm/s
For compound 4 the middle estimate is 2.9-fold (0.46 log units) below the measured one, outside the stated range (above it).
By their numbers in this assay, from the lowest: compounds 3 and 1 (each within the scatter of the next); then compound 4.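

In this assay, the group on this carbon of the shared core can shift the number beyond the scatter: a 3.2-fold higher number from compound 3 to compound 4 (0.50 log units; beyond the scatter) with 3,5-dimethylphenyl in place of 4-methylphenyl, although both groups are carbon-only aromatic rings with no hydrogen-bond donors or acceptors and no net charge. The other new step, a 2.5-fold higher number from compound 1 to compound 4 (0.39 log units; beyond the scatter), shows that compound 4 also stands apart from compound 1, whereas compound 3 and compound 1 remain within the scatter of each other. No measurement shown accounts for either step.

The compounds shown leave open whether the two methyl groups of compound 4 work together or one alone accounts for the step, and compound 2 has no number to compare. As far as these compounds go, how this position responds to an aromatic ring carrying an amine or a carboxylic acid also remains open.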